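The compounds below may be only part of what the source reports. "The series", "measured", "known", "first", "only" and "open" are said of these compounds alone.

Measured so far in an assay on microsomes from intestine for inhibition of acyl-CoA:cholesterol acyltransferase (Oryctolagus cuniculus); on this read-out higher numbers stand for weaker inhibition and lower numbers for stronger inhibition:
compound 1 `CCCCCCCCCCOC(=O)CC(=O)Nc1c(C(C)C)cccc1C(C)C` gives 53 nM
compound 2 `CCCCCCCCCCCCOC(=O)CC(=O)Nc1c(C(C)C)cccc1C(C)C` gives 11 nM
compound 3 `CCCCCCCCCCCCCCCCOC(=O)CC(=O)Nc1c(C(C)C)cccc1C(C)C` gives 35 nM

Compound 3 stands second highest of the three numbers. Its nearest neighbour is compound 1, the gap being a 1.5-fold lower number from compound 1 to compound 3 (0.18 log units; within the scatter), which is within the scatter; its furthest is compound 2, as shown by a 3.2-fold higher number from compound 2 to compound 3 (0.50 log units; beyond the scatter).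

Compound 4 `CCCCCCCCCCCCCCCCCCOC(=O)CC(=O)Nc1c(C(C)C)cccc1C(C)C` is not yet measured. It differs from compound 3 by ethyl in place of hydrogen on a saturated chain carbon, ten or more bonds along the chain from an oxygen next to a carbonyl group.

Within the data shown here, two measured steps bear on this change. The same ethyl-for-hydrogen extension, taken from compound 1, gave a 4.8-fold lower number from compound 1 to compound 2 (0.68 log units; beyond the scatter). The longer extension taken from compound 2, however, gave a 3.2-fold higher number from compound 2 to compound 3 (0.50 log units; beyond the scatter), so lengthening the chain does not run in one direction across these three compounds: the number first falls and then rises again. With only three points and this turn at compound 3, the further extension in compound 4 is expected to give at most a small step, if anything a slightly higher number, a 1.6-fold higher number from compound 3 to compound 4 (0.20 log units; within the scatter). Compound 4 is therefore estimated at 55 nM in this assay, with a range from 15 nM to 200 nM.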

Compound 4, half-maximal inhibitory concentration: 53 nM
Estimate against measurement, compound 4: 1.0-fold (0.02 log units) above; low and high end bracket the measured number.
By their numbers in this assay, from the lowest: compound 2; then compounds 3, 1 and 4 (each within the scatter of the next).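

In this assay the ethyl-for-hydrogen change on a saturated chain carbon does not give one outcome along the series: the same change on two cores in this assay, a 4.8-fold lower number (0.68 log units; beyond the scatter) from compound 1 to compound 2 and a 1.5-fold higher number (0.18 log units; within the scatter) from compound 3 to compound 4, 7.3-fold (0.86 log units) apart, beyond the scatter of two such steps.

Past compound 3 the number stays within the scatter, as a 1.5-fold higher number from compound 3 to compound 4 (0.18 log units; within the scatter) shows, and a 4.8-fold higher number from compound 2 to compound 4 (0.68 log units; beyond the scatter) confirms that the strongest inhibition of the four stays with the intermediate chain, whose steps to all the others are beyond the scatter.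

The two ends of the series are level, with no change at the digits printed from compound 1 to compound 4 (within the scatter) as the reading, and the hexyl change likewise depends on the chain that carries it: the same change on two cores in this assay, a 1.5-fold lower number (0.18 log units; within the scatter) from compound 1 to compound 3 and a 4.8-fold higher number (0.68 log units; beyond the scatter) from compound 2 to compound 4, 7.3-fold (0.86 log units) apart, beyond the scatter of two such steps.

From the compounds shown here alone, it remains open whether a longer chain than that of compound 4 would stay level with it, and how chains of intermediate length would fall around compound 2. Also open, going by these compounds, is how a branched chain, or a carboxylic acid or an amine at the chain end, would read on the shared core.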